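From a six-atom side chain to phenethyl on the core

The source may report more compounds than this note shows. Statements on the series, on what has been measured and on what is new or still open speak of the compounds shown alone.

Compound 1 `CC1=C(N2CC2)C(=O)C(CC(C)OC(N)=O)=C(N2CC2)C1=O`: 5.18
Compound 2 `CCCC1=C(N2CC2)C(=O)C(CCC)=C(N2CC2)C1=O`: 4.14
Compound 3 `COCCC1=C(N2CC2)C(=O)C(CCOC)=C(N2CC2)C1=O`: 4.71

All three values come from a functional assay on L1210 cells (Mus musculus), with a stated time of 1 days; a higher number here means a more potent compound, by a factor of ten per unit of this negative logarithm, a lower number a less potent compound. Compound 1 stands highest of the three: compound 3 is nearest, lower by a margin beyond the scatter, and compound 2 is furthest, lower by a margin also beyond the scatter. Compound 4 `CC1=C(N2CC2)C(=O)C(CCCc2ccccc2)=C(N2CC2)C1=O` has not yet been measured in this assay. It differs from compound 1 in one place: a group of 8 heavy atoms (8 carbon; one six-membered aromatic ring of carbon only) in place of a group of 6 heavy atoms (3 carbon, 1 nitrogen, 2 oxygen; no ring), on a saturated chain carbon bound to a double-bonded ring carbon. Going by the values given here, no step between measured compounds matches this change, so the expectation rests on the spread among compounds 1, 2 and 3, where compound 2, carrying plain chains, gives the lowest value. The step is expected to run downward, estimated at a number 0.78 log units lower from compound 1 to compound 4 (beyond the scatter). For compound 4 the value in this assay is estimated at 4.4, between 3.8 and 5.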

Compound 4, logarithm of the reciprocal of the active concentration, log(1/C): 3.6
Beside the measured number, compound 4's estimate is 0.80 log units above it, outside the stated range (below it).
By their numbers in this assay, from the lowest: compound 4; then compound 2; then compound 3; then compound 1.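

Putting phenethyl in place of the group of 6 heavy atoms, on a saturated chain carbon bound to a double-bonded ring carbon, gives a large fall in this assay, a number 1.58 log units lower from compound 1 to compound 4 (beyond the scatter). Going by these compounds alone, this is the first measured step at this place, and it shows that the result depends strongly on the group carried there. No measurement at hand accounts for the size of the fall. As far as these compounds go, because one step both removes the old group and adds the aromatic ring, their separate contributions remain open. From the compounds shown here alone, how a hydroxyl or an amine at this place would stand in this assay also remains open.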